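The source may hold more compounds than are shown below. What is called first, only, known or untested is meant among the compounds shown, and "the series" means these compounds.

Measured so far in an ADME assay on MT4 cells (Homo sapiens) for activation, read by MTT assay; a lower number here means that less compound is tolerated, a higher number that more compound is tolerated:
- Compound 1, `CCCSc1nc(Cc2c(F)cccc2Cl)c(C)c(=O)[nH]1`, reaches a limit of the assay, > 76000 nM.
- Compound 2, `CCCCSc1nc(Cc2c(F)cccc2Cl)c(C)c(=O)[nH]1`, reaches a limit of the assay, > 73000 nM.
- Compound 3, `CCCSc1nc(C(C)c2c(F)cccc2Cl)cc(=O)[nH]1`, reaches a limit of the assay, > 75000 nM.

All three readings are limits, not numbers. Compound 2 differs from compound 1 by methyl in place of hydrogen on a saturated chain carbon, three bonds along the chain from a sulfur. The step that the two limits leave unreadable from compound 1 to compound 2 cannot be read because the limit of > 76000 nM in this assay, at which 1 of the 3 values shown sits, and the limit of > 73000 nM in this assay, at which 1 of the 3 values shown sits, both cap the readings. How the core of compound 3 differs from the core of compound 1 is not broken down here.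

Compound 4, `CCC(C)Sc1nc(C(C)c2c(F)cccc2Cl)cc(=O)[nH]1`, differs from compound 3 by methyl in place of hydrogen on a saturated chain carbon bound to a saturated chain carbon and a sulfur. This is the same kind of change as from compound 1 to compound 2, though the place differs: here the carbon is bound to a saturated chain carbon and a sulfur, there it lies three bonds along the chain from a sulfur.

The expectation rests on compound 3 giving > 75000 nM and on a step that the two limits leave unreadable from compound 1 to compound 2, which shows no readable effect of an added methyl. Compound 4 is therefore expected to sit at about 75000 nM, most likely again a limit, which would mean a step of a number no higher from compound 3 to compound 4 (the limit leaves the size open).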

Compound 4, half-maximal cytotoxic concentration: > 73000 nM
Compound 4: no number, only a limit; the forecaster's own chance of this, stated with the estimate: 85%; the middle value is on the limit's open side.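

In this assay compound 4 gives > 73000 nM, which is a limit of the assay and not a number. Compound 3 also reads only as a limit, and no step can be read between compound 3 and compound 4. The compounds shown leave open where the half-maximal cytotoxic concentration of any of them lies, and whether an added methyl shifts it at all.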